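Working notes: from compound 3 to compound 4

The source may report more compounds than this note shows. Statements on the series, on what has been measured and on what is new or still open speak of the compounds shown alone.

- compound 1 `Cc1ccc(S(=O)(=O)N[C@@H](CC(=O)NC(C)(C)C)C(=O)NCCNC(=O)c2cc(Cl)ccn2)cc1` gives > 11000 nM (a limit)
- compound 2 `Cc1ccc(S(=O)(=O)N[C@@H](CC(=O)NC(C)(C)C)C(=O)NCCNC(=O)c2cccc(O)c2)cc1` gives > 11000 nM (a limit)
- compound 3 `Cc1ccc(S(=O)(=O)N[C@@H](CC(=O)NC(C)(C)C)C(=O)NCCNC(=O)Nc2ccccc2)cc1` gives > 11000 nM (a limit)

In an ADME assay on HepG2 cells (Homo sapiens) for cytotoxicity (on this read-out higher numbers stand for an effect only at larger amounts of compound and lower numbers for an effect already at smaller amounts), compound 3 stands at > 11000 nM as a limit, not a number. For the measured compounds named here, the series so far offers only the limit of > 11000 nM in this assay, at which 3 of the 3 values shown sit, and no measured number.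

The next change is 2-fluoro-6-hydroxyphenyl in place of anilino on a carbonyl carbon, which leads to compound 4 `Cc1ccc(S(=O)(=O)N[C@@H](CC(=O)NC(C)(C)C)C(=O)NCCNC(=O)c2c(O)cccc2F)cc1` with the shared core left as it is.

Going by the values given here, three measured steps concern this same carbonyl carbon. They are a step that the two limits leave unreadable from compound 2 to compound 3, a step that the two limits leave unreadable from compound 1 to compound 3 and a step that the two limits leave unreadable from compound 1 to compound 2. The first is the closest in kind, as it also exchanges anilino and a hydroxyl-bearing phenyl group, but none of the three has a readable size and none gives a direction.

No step beyond the scatter is therefore expected in this assay. The expected step is a step that the limit leaves unreadable from compound 3 to compound 4 on this estimate. Compound 4 is estimated at 15000 nM, with an expected range of 8000 nM to 40000 nM, and a report as a limit is the likeliest outcome.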

Compound 4, half-maximal effective concentration: > 11000 nM
Compound 4 ended at the assay's limit; the forecaster's own chance of this, stated with the estimate: 85%; the middle value does not contradict the limit.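

In this assay compound 4 gives > 11000 nM, a limit and not a number. The steps to compound 4 from compound 1, compound 2 and compound 3 cannot be read, and the series stays at a single limit: the limit of > 11000 nM in this assay, at which 4 of the 4 values shown sit.

The compounds shown leave open whether any exchange on this carbonyl carbon changes the read-out at all.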